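The compounds below may be only part of what the source reports. "The series", "measured", "known", "first", "only" and "open" are said of these compounds alone.

Measured so far:
compound 1, `C/N=C(/NC#N)NCCCCCn1nc(-c2ccccc2)ccc1=O`: 76.2 mg/kg
compound 2, `CC/N=C(/NC#N)NCCCCCCn1nc(-c2ccccc2)ccc1=O`: > 100 mg/kg

In a functional assay on the whole organism with Rattus norvegicus as the target (a higher number here means that more compound is needed for the effect, a lower number that less compound is needed), compound 1 gives 76.2 mg/kg. Compound 2 gives > 100 mg/kg, which is a limit of the assay and not a number. Among the measured compounds shown here, compound 1 thus stands as the only compound with a number in this assay; the one other value reaches (the limit of > 100 mg/kg in this assay, at which 1 of the 2 values shown sits). For the measured compounds named here, the only measured step, an at least 1.3-fold higher number from compound 1 to compound 2 (0.11 log units; that floor lies within the scatter), runs to a limit, so its true size is unknown.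

Compound 3, `C/N=C(\NC#N)NCCCCn1nc(-c2ccccc2)ccc1=O`, is not yet measured in this assay. It differs from compound 1 by a group of 7 heavy atoms (3 carbon, 4 nitrogen; no ring) in place of a group of 8 heavy atoms (4 carbon, 4 nitrogen; no ring), on a saturated chain carbon, four bonds along the chain from an aromatic nitrogen. Going by the values given here, the single measured step enlarges the group rather than trimming it and only sets a floor within the scatter, so it offers no firm direction for compound 3; no step beyond the scatter is expected. Compound 3 is therefore estimated at 75 mg/kg, with a range of 30 mg/kg to 160 mg/kg, an expected step of a 1.0-fold lower number from compound 1 to compound 3 (0.01 log units; within the scatter).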

Compound 3, dose for half-maximal effect: 38.5 mg/kg
The estimate for compound 3 lay 1.9-fold (0.29 log units) above the measured number; low and high end bracket the measured number.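

In this assay, the change at this position now has a number at both ends (a 2.0-fold lower number from compound 1 to compound 3 (0.30 log units; within the scatter)). That step is printed as within the scatter, so a group of 7 heavy atoms in place of a group of 8 heavy atoms, on a saturated chain carbon, four bonds along the chain from an aromatic nitrogen, does not separate compound 3 from compound 1 in this read-out. Compound 2 still carries only a limit of the assay and not a number, which leaves no second measured size to set against this step: the limit of > 100 mg/kg in this assay, at which 1 of the 3 values shown sits.

The compounds shown leave open whether any change at this place moves the dose beyond the scatter. An amine or a carboxylic acid on the saturated chain carbon would test this, as would a shorter chain.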